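Swapping trifluoromethyl for methoxy on a benzyl urea

The source may report more compounds than this note shows. Statements on the series, on what has been measured and on what is new or still open speak of the compounds shown alone.

Compound 1 `O=C(NCc1ccccc1C(F)(F)F)N1C(=O)c2ccccc2S1(=O)=O`: 0.187 h
Compound 2 `O=C(NCc1cccc2ccccc12)N1C(=O)c2ccccc2S1(=O)=O`: 0.395 h
Compound 3 `O=C(OCc1ccccc1)N1C(=O)c2ccccc2S1(=O)=O`: a limit, < 0.0167 h

The three measured compounds share one core and differ only in the group attached to it. In a physicochemical assay for pharmacokinetics (a higher number here means that the compound lasts longer, a lower number that the compound disappears faster), compound 1 gives 0.187 h, the lowest of the two numbers that were read. Compound 2 gives 0.395 h, a higher number whose gap to compound 1 lies beyond the scatter. For compound 3 the assay reports only a limit, < 0.0167 h, which is the bound of the assay, (the limit of < 0.0167 h in this assay, at which 1 of the 3 values shown sits), and not a number.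

Compound 4 `COc1ccccc1CNC(=O)N1C(=O)c2ccccc2S1(=O)=O` has not yet been measured. It is built from compound 1 by one change: methoxy in place of trifluoromethyl on an aromatic carbon. Within the data shown here, no measured pair shows a step of this kind, so the expectation rests on compound 1 alone and on the spread between compound 1 and compound 2. A small step is expected, most likely none beyond the scatter, with a slight lean toward a lower number. In this assay compound 4 is expected to give about 0.15 h, within 0.05 h to 0.45 h. The step from compound 1 to compound 4 is then estimated as a 1.2-fold lower number from compound 1 to compound 4 (0.10 log units; within the scatter).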

Compound 4, half-life: 1.12 h
Beside the measured number, compound 4's estimate is 7.5-fold (0.87 log units) below it, outside the stated range (above it).
By their numbers in this assay, from the lowest: compound 1; then compound 2; then compound 4. At a limit, below all of these: compound 3.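

In this assay the change of methoxy in place of trifluoromethyl on an aromatic carbon gives a 6.0-fold higher number from compound 1 to compound 4 (0.78 log units; beyond the scatter) with nothing else in the molecule altered, so the group at this place clearly bears on how long the compound lasts. The earlier compounds could not show this, as no two of them differ in one place only, and this pair is the only direct comparison of its kind among the compounds shown. The numbers show the size and direction of the step, but nothing measured here accounts for it.

A single pair cannot separate what methoxy adds from what the loss of trifluoromethyl removes, and it cannot tell whether the same swap would have a similar effect with a different group elsewhere on the shared core. Placing a hydroxyl group, an amine, a longer chain such as ethoxy, or just a hydrogen on this same aromatic carbon would show whether the higher number belongs to methoxy alone or extends to other groups.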